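This account rests on a few compounds, and the source may have more. Where it says the series, first, only, none or still open, it means among the compounds named here.

Working notes on the series. Compound 1 `COC(=O)NC1=NC(c2ccccc2C)CN1` gives 55 mg/kg in a functional assay on the whole organism for antagonist activity, with Mus musculus as the target, in the maximal electroshock model; a higher number here means that more compound is needed for the effect, a lower number that less compound is needed. For the measured compounds named here, compound 2 `COC(=O)NC1=NC(c2ccccc2F)CN1` gives 54 mg/kg in this assay; the one measured step between two compounds differing in a single place, a 1.0-fold lower number from compound 1 to compound 2 (0.01 log units; within the scatter), is a change on an aromatic carbon and lies within the scatter. Compound 3 `COC(=O)NC1=NC(c2ccccc2)CN1C` gives 107 mg/kg in this assay; this is the highest of the three numbers, yet its gaps to compound 1 and to compound 2 both lie within the scatter, so no order among the three can be read from these values.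

Compound 4 `CCOC(=O)NC1=NC(c2ccccc2)CN1C` differs from compound 3 by methyl in place of hydrogen on a saturated chain carbon bound to an oxygen next to a carbonyl group. Going by the values given here, no measured step touches this part of the molecule: the step from compound 1 to compound 2 concerns the aromatic ring, was itself within the scatter, and gives no guide to a change at the methoxycarbonyl group, neither in size nor in direction. With nothing bearing on it, the expected step of no change at the digits printed from compound 3 to compound 4 (within the scatter) is none beyond the scatter. Compound 4 is therefore estimated at 107 mg/kg in this assay, with a range from 50 mg/kg to 230 mg/kg.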

Compound 4, dose for half-maximal effect: 78 mg/kg
The estimate for compound 4 lay 1.4-fold (0.14 log units) above the measured number; the measured number falls inside the stated range.
By their numbers in this assay, from the lowest: compounds 2, 1, 4 and 3 (each within the scatter of the next).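

For the compounds shown here, the step of a 1.4-fold lower number from compound 3 to compound 4 (0.14 log units; within the scatter) in this assay is the first measured change at the methoxycarbonyl group, and it shows that methoxycarbonyl to ethoxycarbonyl, one added methyl on a saturated chain carbon bound to an oxygen next to a carbonyl group, does not move the number beyond the scatter. The earlier step concerned only the aromatic ring, so this part of the molecule now has a measured step of its own, and this step too stays within the scatter. Nothing available explains this outcome.

As far as these compounds go, one step within the scatter gives no trend with chain length, so a longer chain such as butoxycarbonyl remains open, as does a bulkier group such as benzyloxycarbonyl. From the compounds shown here alone, whether an amine or a carboxylic acid at this end would leave the number within the scatter also remains open.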